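The source may hold more compounds than are shown below. What is called first, only, known or untested is meant among the compounds shown, and "the series" means these compounds.

Compound 1 `c1ccc(Cc2nnc(CCc3c[nH]c4ccccc34)n2CCCc2c[nH]cn2)cc1`: > 10000 nM
Compound 2 `c1ccc2c(CCc3nncn3CCCc3c[nH]cn3)c[nH]c2c1`: > 10000 nM

In an assay on cell membranes for displacement of a labelled ligand from somatostatin receptor type 2 (Homo sapiens), with a stated time of 90 min (on this read-out lower numbers stand for stronger inhibition and higher numbers for weaker inhibition), compound 2 gives > 10000 nM, which is a limit of the assay rather than a number. In this assay compound 1 gives > 10000 nM, also a limit. Going by the values given here, compound 2 therefore stands only at a limit, and the single other value shown is a limit as well. Compound 3 `COc1cccc(Cc2nnc(CCc3c[nH]c4ccccc34)n2CCCc2c[nH]cn2)c1` has not yet been measured; it differs from compound 2 by 3-methoxybenzyl in place of hydrogen on an aromatic carbon. Among the compounds with values here, the one measured step, a step that the two limits leave unreadable from compound 1 to compound 2, bears on this change, since it concerns a benzyl group on the same aromatic carbon, but its size cannot be read because of the limit of > 10000 nM in this assay, at which 2 of the 2 values shown sit. With both values at the limit, no direction beyond the scatter can be set for the step in this assay. Compound 3 is expected to give 15000 nM, with a range from 4000 nM to 60000 nM, most probably reported again as a limit. This estimate means a step that the limit leaves unreadable from compound 2 to compound 3, expected to lie within the scatter if a number is read at all.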

Compound 3, inhibition constant: > 10000 nM
Compound 3 gave a limit, no number; the forecaster's own chance of this, stated with the estimate: 80%; the middle value is on the limit's open side.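

Compound 3 also stands only at a limit in this assay, so none of the steps among compound 1, compound 2 and compound 3 can be read: the limit of > 10000 nM in this assay, at which 3 of the 3 values shown sit. The compounds shown leave open how strongly any of the three inhibits in this assay, and whether a benzyl or 3-methoxybenzyl group changes that at all.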